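A few compounds are considered here, and "the series" means these few. Any claim that something is new, unique, unknown or untested is made for them only; others in the source may bear on it.

Among the compounds with values here, compound 1 `O=C(Nc1ccc(Nc2ncnc3c2OCCN3)cc1)Nc1ccc(C(F)(F)F)cc1` is one of two compounds measured in an assay on isolated protein for inhibition of proto-oncogene tyrosine-protein kinase receptor Ret variant V804L (Homo sapiens), read by 33P incorporation, with stated times of 15 min and 40 min (a higher number here means a weaker inhibitor, a lower number a stronger inhibitor), and compound 1 gives 2470 nM, the lower of the two numbers and so the stronger inhibitor of the pair. The other is compound 2 `Cc1ccc(F)c(NC(=O)Nc2ccc(Nc3ncnc4c3OCCN4)cc2)c1`, which in this assay gives 7000 nM; that step, a 2.8-fold higher number from compound 1 to compound 2 (0.45 log units; beyond the scatter), comes from swapping the group on one amide-type nitrogen, with 2-fluoro-5-methylphenyl in place of 4-(trifluoromethyl)phenyl, and it weakens the inhibitor to a modest degree.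

The unmeasured compound 3 `O=C(Nc1ccc(Nc2ncnc3c2OCCN3)cc1)Nc1cccc2ccccc12` changes the same position in another way: naphthalen-1-yl in place of 4-(trifluoromethyl)phenyl on an amide-type nitrogen. Within the data shown here, the only measured step that bears on it is the one from compound 1 to compound 2, since it alters the same group at the same place, and it was modest and toward weaker inhibition. On that slender basis, a step of similar size in this assay, most likely toward a higher number but possibly none beyond the scatter, is expected, a 1.4-fold higher number from compound 1 to compound 3 (0.15 log units; within the scatter). Compound 3 is therefore estimated at 3500 nM, with a plausible range from 1200 nM to 10000 nM.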

Compound 3, half-maximal inhibitory concentration: > 10000 nM
Compound 3: only a limit was reported; the forecaster's own chance of this, stated with the estimate: 10%; at least 2.8-fold (0.45 log units) between middle value and limit.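

Compound 3 carries only a limit in this assay, not a true number: the limit of > 10000 nM in this assay, at which 1 of the 3 values shown sits. Even so, the limit is enough to show that this place on the amide-type nitrogen does not accept every aromatic group equally: naphthalen-1-yl in place of 4-(trifluoromethyl)phenyl gives an at least 4.0-fold higher number from compound 1 to compound 3 (0.60 log units; beyond the scatter) and so loses inhibition even though both groups have the same number of heavy atoms, and neither has a hydrogen-bond donor or acceptor, leaving compound 1 the strongest inhibitor of the three. The comparison with the other substituted phenyl group is less firm, as naphthalen-1-yl in place of 2-fluoro-5-methylphenyl gives an at least 1.4-fold higher number from compound 2 to compound 3 (0.15 log units; that floor lies within the scatter) and this does not clearly separate the two compounds.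

As far as these compounds go, how far compound 3 really lies beyond its limit stays unknown, so the true size of both new steps is open. The compounds shown also leave open how this place would respond to a group carrying an amine or a carboxylic acid, or to a plain phenyl group with no substituent, either of which could help show which features of 4-(trifluoromethyl)phenyl matter here.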